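A few compounds are considered here, and "the series" means these few. Any claim that something is new, unique, unknown or untested is made for them only; others in the source may bear on it.

Compound 1 `CC(=O)N1N=C(c2ccc(F)cc2)CC1c1cn(-c2ccccc2)nc1-c1ccc(C)cc1` and compound 3 `Cc1ccc(-c2nn(-c3ccccc3)cc2C2CC(c3ccc(F)cc3)=NN2c2ccccc2)cc1` share a core that differs by phenyl in place of acetyl on an amine nitrogen in a ring. In a functional assay on the whole organism (Tail) with Rattus norvegicus as the target, in the tail flick test, with a stated time of 60 min, at a dose of 25 mg/kg by the oral route (a lower number here means less inhibition, a higher number more inhibition at the dose given (going by the name of the read-out)), compound 1 gives 110%, and compound 3 gives 110%; the step of no change at the digits printed from compound 1 to compound 3 (within the scatter) lies within the scatter. Compound 2 `COc1ccc(-c2nn(-c3ccccc3)cc2C2CC(c3ccc(F)cc3)=NN2C(C)=O)cc1` carries the change methoxy in place of methyl on an aromatic carbon on the core of compound 1, and in this assay compound 2 gives 66%, a step of a number 44 percentage points lower from compound 1 to compound 2 (beyond the scatter). Compound 4 `COc1ccc(-c2nn(-c3ccccc3)cc2C2CC(c3ccc(F)cc3)=NN2c2ccccc2)cc1` is not yet measured; it carries the change methoxy in place of methyl on an aromatic carbon on the core of compound 3, the same change that was made from compound 1 to compound 2, at the same place. Because the earlier step of a number 44 percentage points lower from compound 1 to compound 2 (beyond the scatter) was large, a comparable drop is expected for compound 4, namely a number 42 percentage points lower from compound 3 to compound 4 (beyond the scatter) in this assay. Compound 4 is therefore estimated at 68%, expected to fall between 45% and 95%.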

Compound 4, a percentage reported as inhibition, in the whole organism at one dose (the size of the read-out at that dose, not a potency): 66%
For compound 4 the middle estimate is 2 percentage points above the measured one; low and high end bracket the measured number.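

Methoxy in place of methyl gave a number 44 percentage points lower from compound 3 to compound 4 (beyond the scatter) in this assay, which carries the earlier step over to a second core: the same change on two cores in this assay, a number 44 percentage points lower (beyond the scatter) from compound 1 to compound 2 and a number 44 percentage points lower (beyond the scatter) from compound 3 to compound 4, 0 percentage points apart, within the scatter of two such steps. Phenyl in place of acetyl on an amine nitrogen in a ring gave no change at the digits printed from compound 2 to compound 4 (within the scatter), again matching the earlier step: the same change on two cores in this assay, no change at the digits printed (within the scatter) from compound 1 to compound 3 and no change at the digits printed (within the scatter) from compound 2 to compound 4, 0 percentage points apart, within the scatter of two such steps. Going by these compounds alone, these four compounds show that each change gave the same step on both cores, but they cover only this pair of changes at one dose and do not show that either step would hold on any other core.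

The compounds shown leave open what a chloro, hydroxyl or amine group would give in place of the methoxy or methyl. They also leave open what a longer chain or a carboxylic acid would give in place of the acetyl or phenyl.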